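This account rests on a few compounds, and the source may have more. Where it says the series, first, only, none or still open, it means among the compounds named here.

Series notes. Compound 1 `Nc1ccc2nc(N)sc2c1` and compound 2 `N#CCn1c(=N)sc2cc(OC(F)(F)F)ccc21` share the core; compound 3 `N=c1sc2cc(OC(F)(F)F)ccc2n1CCSc1ccccc1` is the unmeasured member. In a functional assay on the whole organism with Rattus norvegicus as the target (a lower number here means that less compound is needed, a higher number that more compound is needed for the effect), compound 1 gives > 10 mg/kg, which is a limit of the assay and not a number. In this assay compound 2 gives 3.5 mg/kg. That is the only number shown so far in this assay; the other entry is a limit, as set out in the limit of > 10 mg/kg in this assay, at which 1 of the 2 values shown sits. Compound 2 therefore stands alone as the single measured dose, with no second number to rank it against.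

Change from compound 2 to compound 3: (phenylsulfanyl)methyl in place of cyano on a saturated chain carbon bound to an aromatic nitrogen. The saturated chain carbon bound to the aromatic nitrogen is kept; only the group on it is exchanged. Going by the values given here, no step between measured compounds exists in this assay, so the data give no direction for this exchange. The expected step is a 1.1-fold higher number from compound 2 to compound 3 (0.06 log units; within the scatter) in this assay, which is none beyond the scatter. Compound 3 is estimated at 4 mg/kg in this assay, with a range from 1.5 mg/kg to 12 mg/kg, the width reflecting the absence of any measured step.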

Compound 3, dose for half-maximal effect: 4.5 mg/kg
Estimate against measurement, compound 3: 1.1-fold (0.05 log units) below; low and high end bracket the measured number.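

In this assay the series now has its first step between measured compounds, a 1.3-fold higher number from compound 2 to compound 3 (0.11 log units; within the scatter). At this place, on a saturated chain carbon bound to an aromatic nitrogen, cyano with 2 heavy atoms and no ring and (phenylsulfanyl)methyl with 8 heavy atoms and a six-membered aromatic ring of carbon only therefore read alike in this assay, so this much larger group leaves the dose within the scatter of the smaller one. Compound 1 still adds no step to this picture, because its entry is a limit of the assay and not a number: the limit of > 10 mg/kg in this assay, at which 1 of the 3 values shown sits.

From the compounds shown here alone, whether this place accepts other groups equally well remains open, since a single pair cannot show a trend and an amine, a carboxylic acid or a longer chain on the same carbon could read differently. The pair also does not show why cyano and (phenylsulfanyl)methyl read alike, or whether the same exchange would hold on a core carrying a different substituent.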